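Changing the acyl aryl group of compound 3

A few compounds are considered here, and "the series" means these few. Any claim that something is new, unique, unknown or untested is made for them only; others in the source may bear on it.

Of the compounds shown here, three have so far been tested in a functional assay on HeLa cells (Homo sapiens) for antiproliferative activity, with a stated time of 24 h; a higher number here means a weaker inhibitor, a lower number a stronger inhibitor. Compound 1 `NC(=O)c1c(NC(=O)c2ccccc2Cl)sc2c1CCN(C(=S)Nc1ccccc1)C2` gives 46700 nM in this assay. Compound 2 `Cc1ccccc1NC(=S)N1CCc2c(sc(NC(=O)c3ccccc3Cl)c2C(N)=O)C1` reaches only the limit of the assay, > 50000 nM, in this assay. Compound 3 `NC(=O)c1c(NC(=O)c2ccccc2Br)sc2c1CCN(C(=S)Nc1ccccc1Cl)C2` gives 46900 nM in this assay, and its number and that of compound 1 lie within the scatter of each other. For the measured compounds named here, the one measured step, an at least 1.0-fold higher number from compound 1 to compound 2 (0.02 log units; that floor lies within the scatter), stays within the scatter, and one of the three values sits at the limit of > 50000 nM in this assay, at which 1 of the 3 values shown sits.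

Compound 4 `Cc1ccc(C(=O)Nc2sc3c(c2C(N)=O)CCN(C(=S)Nc2ccccc2Cl)C3)cc1` differs from compound 3 in one place: 4-methylphenyl in place of 2-bromophenyl on a carbonyl carbon. Going by the values given here, no measured pair shows this exchange, and the single measured step concerns a different position and is itself flat. Every measured compound is weak in this assay. Compound 4 is therefore expected to be weak as well, with a step of a 1.1-fold higher number from compound 3 to compound 4 (0.03 log units; within the scatter) that most likely stays within the scatter. For compound 4 the estimate in this assay is 50000 nM, between 25000 nM and 100000 nM.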

Compound 4, half-maximal inhibitory concentration: 26300 nM
Compound 4: middle estimate off by 1.9-fold (0.28 log units), on the high side; low and high end bracket the measured number.
By their numbers in this assay, from the lowest: compounds 4, 1 and 3 (each within the scatter of the next). At a limit, above all of these: compound 2.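

In this assay, the exchange of 2-bromophenyl for 4-methylphenyl on a carbonyl carbon gives the first step read at this position: a 1.8-fold lower number from compound 3 to compound 4 (0.25 log units; within the scatter). The earlier compounds shown here showed only a flat step elsewhere on the shared core, whereas this step shows that one substituted phenyl can stand in for another here with the result staying within the scatter. The value for compound 2 remains a limit of the assay, so it gives no number to compare: the limit of > 50000 nM in this assay, at which 1 of the 4 values shown sits.

This single step replaces bromine with methyl and also alters the substitution pattern of the ring, so it cannot separate those two parts of the change. It also leaves open how this assay responds when a carboxylic acid, an amine or a longer alkyl chain stands in place of the 4-methylphenyl.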